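A ring swap on an amide-type nitrogen

The source may hold more compounds than are shown below. What is called first, only, known or untested is meant among the compounds shown, and "the series" means these compounds.

In an ADME assay on BaF3 cells (Mus musculus) for antiproliferative activity, read by CCK-8 assay, with a stated time of 72 h (on this read-out higher numbers stand for weaker inhibition of growth and lower numbers for stronger inhibition of growth), compound 1 `Cc1ccc(C(=O)Nc2ccc(CN3CCN(C)CC3)c(C(F)(F)F)c2)cc1C#Cc1ncc2cccnn12` gives 940 nM and compound 2 `O=C(CCSc1ccc2c(/C=C/c3ccccn3)n[nH]c2c1)Nc1cccc(F)c1` gives 6590 nM. Compound 2 thus holds the higher of the two numbers, with weaker inhibition of growth, and the gap lies beyond the scatter. Compound 3 `Cc1ccc(NC(=O)CCSc2ccc3c(/C=C/c4ccccn4)n[nH]c3c2)cc1` carries 4-methylphenyl in place of 3-fluorophenyl on an amide-type nitrogen. Going by the values given here, no measured pair shows this exchange, so the expectation rests on compound 2 at 6590 nM alone, and no change beyond the scatter is expected in this assay. The estimated step is a 1.3-fold lower number from compound 2 to compound 3 (0.12 log units; within the scatter). Compound 3 is expected at 5000 nM, with an estimated range of 1800 nM to 13000 nM.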

Compound 3, concentration for 50% growth inhibition: > 10000 nM
Compound 3 gave a limit, no number (the forecaster's own chance of this, stated with the estimate: 10%); at least 2.0-fold (0.30 log units) between middle value and limit.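

In this assay compound 3 gives a limit and not a number: the limit of > 10000 nM in this assay, at which 1 of the 3 values shown sits. The exchange on the amide-type nitrogen amounts to an at least 1.5-fold higher number from compound 2 to compound 3 (0.18 log units; that floor lies within the scatter). On these data alone, this shows that 4-methylphenyl in this place brings no stronger inhibition of growth, but the size of the loss remains unknown, and the floor alone does not separate the two compounds.

The compounds shown leave open whether unsubstituted phenyl, or a phenyl ring carrying an amine or a carboxylic acid, would lower the number at this position.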